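Swapping methylamino for 4-methylpiperazin-1-yl on a shared core

The source may hold more compounds than are shown below. What is called first, only, known or untested is meant among the compounds shown, and "the series" means these compounds.

Of the compounds shown here, three sharing one core have been measured in a physicochemical assay for solubility, in phosphate buffer, with a stated time of 2 h; on this read-out higher numbers stand for higher solubility and lower numbers for lower solubility. Compound 1 `Cc1nc(-c2ccc(-c3ccccc3)cc2)sc1-c1nnc(N2CC(O)C2)o1` gives 150000 nM, compound 2 `Cc1nc(-c2ccc(-c3ccccc3)cc2)sc1-c1nnc(NN)o1` gives 77000 nM, and compound 3 `CNC(=N)Nc1nnc(-c2sc(-c3ccc(-c4ccccc4)cc3)nc2C)o1` gives 89000 nM. Compound 3 cannot be separated from the other two, as all three numbers lie within the scatter of each other.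

Compound 4 `Cc1nc(-c2ccc(-c3ccccc3)cc2)sc1-c1nnc(NC(=N)N2CCN(C)CC2)o1` differs from compound 3 by 4-methylpiperazin-1-yl in place of methylamino on a carbon with a double bond to nitrogen. Within the data shown here, no measured step makes this exchange, so the evidence is indirect. The nearest guides are a 1.2-fold higher number from compound 2 to compound 3 (0.06 log units; within the scatter), a 1.7-fold lower number from compound 1 to compound 3 (0.23 log units; within the scatter) and a 1.9-fold lower number from compound 1 to compound 2 (0.29 log units; within the scatter), and each lies within the scatter. On that basis, no step beyond the scatter is expected in this assay, and no direction is favoured. The expected step is a 1.0-fold higher number from compound 3 to compound 4 (0.00 log units; within the scatter). For compound 4 the estimate is 90000 nM, with an expected range from 35000 nM to 200000 nM.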

Compound 4, solubility: 104000 nM
Compound 4: middle estimate off by 1.2-fold (0.06 log units), on the low side; the range from low to high includes it.
By their numbers in this assay, from the lowest: compounds 2, 3, 4 and 1 (each within the scatter of the next).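

In this assay, 4-methylpiperazin-1-yl in place of methylamino on a carbon with a double bond to nitrogen gives a 1.2-fold higher number from compound 3 to compound 4 (0.07 log units; within the scatter), so this place accepts a group with one six-membered non-aromatic ring in place of a group with no ring without a step beyond the scatter. The other new steps, a 1.4-fold higher number from compound 2 to compound 4 (0.13 log units; within the scatter) and a 1.4-fold lower number from compound 1 to compound 4 (0.16 log units; within the scatter), also stay within the scatter, which leaves all four compounds unseparated in this assay. No measured evidence bears on this result.

From the compounds shown here alone, whether a group of another kind on the same carbon, such as a carboxylic acid or a longer alkyl chain, would give a step beyond the scatter remains open. So does whether the 4-methylpiperazin-1-yl exchange would give a similar step on any other core.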